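The compounds below may be only part of what the source reports. "The series", "measured", "known", "first", "only" and "open" are said of these compounds alone.

Compound 3 `CC(C)CN(c1ccc(C#N)cc1)S(=O)(=O)c1ccc2c(c1)C(=O)CC(C1CCOCC1)O2` gives 3.16 in a physicochemical assay for lipophilicity, at pH 7.4 (on this read-out higher numbers stand for higher lipophilicity and lower numbers for lower lipophilicity), the lowest of the three measured numbers. Compound 1 `CC(C)CN(c1ccc(N(C)C)cc1)S(=O)(=O)c1ccc2c(c1)C(=O)CC(C1CCOCC1)O2` gives 3.6 in this assay, and compound 2 `CC(C)CN(c1cc2ccccc2s1)S(=O)(=O)c1ccc2c(c1)C(=O)CC(C1CCOCC1)O2` gives 4.01 in this assay, so compound 3 sits a number 0.44 log units lower from compound 1 to compound 3 (beyond the scatter) and a number 0.85 log units lower from compound 2 to compound 3 (beyond the scatter).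

Compound 4 `CC(C)CN(c1ccccc1F)S(=O)(=O)c1ccc2c(c1)C(=O)CC(C1CCOCC1)O2` differs from compound 3 in one place: 2-fluorophenyl in place of 4-cyanophenyl on a sulfonamide nitrogen. Going by the values given here, no measured step covers this exact exchange on the sulfonamide nitrogen. Among the compounds with values here, two steps bear on it indirectly: the step of a number 0.44 log units lower from compound 1 to compound 3 (beyond the scatter) shows that bringing in cyano lowered the number, and the step of a number 0.85 log units lower from compound 2 to compound 3 (beyond the scatter) shows that the 4-cyanophenyl group gave the lowest of the three groups on that nitrogen. Taking the cyano group away again, with its one hydrogen-bond acceptor, is therefore expected to move the number back up by a modest amount, beyond the scatter. Compound 4 is expected to give 3.7 in this assay, in the range 3.3 to 4.1. That corresponds to an expected step of a number 0.54 log units higher from compound 3 to compound 4 (beyond the scatter).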

Compound 4, distribution coefficient: 3.44
Compound 4: the middle estimate sits 0.26 log units above what was measured, within the range that was stated.
By their numbers in this assay, from the lowest: compounds 3, 4 and 1 (each within the scatter of the next, the first and the last beyond it); then compound 2.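

In this assay, putting 2-fluorophenyl in place of 4-cyanophenyl on the sulfonamide nitrogen gives a number 0.28 log units higher from compound 3 to compound 4 (within the scatter), so losing the nitrile and its hydrogen-bond acceptor leaves the two compounds inside the scatter of each other. Against 4-(dimethylamino)phenyl the same group gives a number 0.16 log units lower from compound 1 to compound 4 (within the scatter), also inside the scatter, whereas against 1-benzothiophen-2-yl it gives a number 0.57 log units lower from compound 2 to compound 4 (beyond the scatter), beyond it. Compound 4 therefore cannot be told apart from either compound 1 or compound 3, even though those two stand beyond the scatter of each other, and of the three earlier groups only 1-benzothiophen-2-yl stands clear of 2-fluorophenyl.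

Nothing shown here gives a reason for these numbers. Still open, on these data alone, is how plain phenyl, a carboxylic acid on the phenyl ring or a saturated alkyl chain would read on this nitrogen in this assay.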